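Cytotoxicity of thioether pyrimidinones: a cyclopentyl swap

The source may hold more compounds than are shown below. What is called first, only, known or untested is meant among the compounds shown, and "the series" means these compounds.

Measured so far in an ADME assay on MT4 cells (Homo sapiens) for activation, read by MTT assay; a higher number here means that more compound is tolerated, a lower number that less compound is tolerated:
- compound 1, `CCCCSc1nc(Cc2c(F)cccc2Cl)c(C)c(=O)[nH]1`, gives > 73000 nM, which is a limit of the assay and not a number
- compound 2, `Cc1c(Cc2c(F)cccc2Cl)nc(SC2CCCC2)[nH]c1=O`, gives > 71000 nM, again a limit of the assay
- compound 3, `CCCCSc1nc(C(CC)c2c(F)cccc2Cl)c(C)c(=O)[nH]1`, gives > 3000 nM, also a limit of the assay

Two changes connect these compounds. From compound 1 to compound 2 the change is cyclopentyl in place of butyl on a sulfur, and its step in this assay is a step that the two limits leave unreadable from compound 1 to compound 2; the reason is that the values involved are limits, namely the limit of > 73000 nM in this assay, at which 1 of the 3 values shown sits, and (the limit of > 71000 nM in this assay, at which 1 of the 3 values shown sits). From compound 1 to compound 3 the change is ethyl in place of hydrogen on a saturated chain carbon bound to two aromatic carbons, and its step is a step that the two limits leave unreadable from compound 1 to compound 3, again because both ends are limits, the limit of > 73000 nM in this assay, at which 1 of the 3 values shown sits, and (the limit of > 3000 nM in this assay, at which 1 of the 3 values shown sits).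

Compound 4, `CCC(c1nc(SC2CCCC2)[nH]c(=O)c1C)c1c(F)cccc1Cl`, has not yet been measured. It differs from compound 3 by cyclopentyl in place of butyl on a sulfur, the same change as from compound 1 to compound 2, made on the same kind of sulfur. The cores of compound 3 and compound 4 differ from those of compound 1 and compound 2 by ethyl in place of hydrogen on a saturated chain carbon bound to two aromatic carbons.

With the earlier step unreadable, the expectation for compound 4 rests on compound 3 alone, whose value > 3000 nM is a limit. Compound 4 is expected to show a step that the limit leaves unreadable from compound 3 to compound 4 from compound 3, an estimate rather than a measurement. The value of compound 4 is estimated at 20000 nM, within the range 3000 nM to 80000 nM.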

Compound 4, half-maximal cytotoxic concentration: > 3000 nM
Compound 4 gave a limit, no number; the forecaster's own chance of this, stated with the estimate: 70%; the middle value does not contradict the limit.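

In this assay compound 4 gives > 3000 nM, which is a limit of the assay and not a number. No new step can be read from compound 3 to compound 4 or from compound 2 to compound 4 because both ends of each pair are limits: the limit of > 3000 nM in this assay, at which 2 of the 4 values shown sit.

The compounds shown leave open at what concentration compound 1, compound 2, compound 3 or compound 4 harms the cells, and whether either change shifts that concentration.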